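The source may report more compounds than this note shows. Statements on the series, on what has been measured and on what is new or still open speak of the compounds shown alone.

In a functional assay on NCI-H460 cells (Homo sapiens) for antiproliferative activity, read by CCK-8 assay, with a stated time of 72 h, tested at 8 uM (on this read-out lower numbers stand for a weaker effect and higher numbers for a stronger effect at the one concentration tested), three compounds built on a shared core have been measured. Compound 3 `CC(C)n1cnc2c(Nc3cccc(Cl)c3)nc(NCOCc3ccc(/C=C/C(=O)Nc4ccccc4N)cc3)nc21` gives 61.1%. Compound 2 `Nc1ccccc1NC(=O)/C=C/c1ccc(COCNc2nc(Nc3cccc(Cl)c3)c3ncn(C4CCCC4)c3n2)cc1` gives 46.1%, and compound 1 `CC(C)n1cnc2c(Nc3ccccc3)nc(NCOCc3ccc(C(=O)Nc4ccccc4N)cc3)nc21` gives 34.3%, the lowest of the three, with the gaps to compound 2 and to compound 3 both beyond the scatter. Compound 2 differs from compound 3 in one place: cyclopentyl in place of isopropyl on an aromatic nitrogen. That change made a step of a number 15 percentage points lower from compound 3 to compound 2 (beyond the scatter). How compound 1 differs from compound 3 is not broken down here, as the two differ in more than one place.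

Compound 4 `Nc1ccccc1NC(=O)c1ccc(COCNc2nc(Nc3ccccc3)c3ncn(C4CCCC4)c3n2)cc1` has not yet been measured in this assay. It is related to compound 1 by exactly the same change: cyclopentyl in place of isopropyl on an aromatic nitrogen. Among the compounds with values here, since the place of the change is the same as from compound 3 to compound 2, compound 4 is expected to fall below compound 1 by a similar amount, a step of about a number 13.3 percentage points lower from compound 1 to compound 4 (beyond the scatter), resting on the one observed step of a number 15 percentage points lower from compound 3 to compound 2 (beyond the scatter). Compound 4 is therefore estimated at 21%, with a range from 7% to 36%.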

Compound 4, a percentage reported as inhibition, at one concentration (the size of the read-out at that concentration, not a potency): 56.1%
Compound 4: middle estimate off by 35.1 percentage points, on the low side, outside the stated range (above it).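

In this assay, cyclopentyl in place of isopropyl on an aromatic nitrogen made a step of a number 21.8 percentage points higher from compound 1 to compound 4 (beyond the scatter). Set beside the earlier pair, the same change went in the opposite direction on the two cores, so a step seen on one core could not be carried over to the other: the same change on two cores in this assay, a number 15 percentage points lower (beyond the scatter) from compound 3 to compound 2 and a number 21.8 percentage points higher (beyond the scatter) from compound 1 to compound 4, 36.8 percentage points apart, beyond the scatter of two such steps. This shows that, in this series, the outcome of the change depends on the core that carries it, but two pairs do not show which of the several differences between the cores is responsible, nor how the change would behave on any further core.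

The compounds shown carry only isopropyl and cyclopentyl on this nitrogen, which leaves open how a methyl group, a longer chain such as n-butyl or a ring bearing an amine would behave there. They also do not separate the chlorine from the carbon-carbon double bond as the feature that goes with the reversal.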